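The compounds below may be only part of what the source reports. "The series", "measured", "known", "first", "only" and "open" are said of these compounds alone.

Measured so far in a toxicity assay on HEK293 cells (Homo sapiens) for inhibition, read by MTT assay, with a stated time of 72 h; a higher number here means a weaker inhibitor, a lower number a stronger inhibitor:
- compound 1 `CC(C)[C@@H]1CC[C@@H](C)C[C@@H]1n1cc(CN2C(=O)C(=O)c3ccccc32)nn1` gives 23100 nM
- compound 2 `Cc1ccc2c(c1)C(=O)C(=O)N2Cc1cn(Cc2ccccc2)nn1` gives 26900 nM
- compound 3 `O=C1N(Cc2cn(Cc3ccccc3)nn2)c2ccccc2[C@@]1(O)c1ccsc1` gives 46400 nM

Compound 3 carries the number at the top of this short set, but its gap to compound 2 and its gap to compound 1 both lie within the scatter, so the three compounds cannot be told apart on the readings in hand and nothing can be said about which is the weaker or stronger inhibitor. Going by the values given here, no pair of the measured compounds differs in a single place, so no measured step is available to calibrate what follows.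

Compound 4 `O=C1N(Cc2cn(Cc3ccccc3)nn2)c2ccccc2[C@]1(O)c1ccsc1` is the next compound to be measured. Its relation to compound 3: the two compounds have the same atoms and bonds and differ only in configuration as drawn: 1 of 1 stereo elements differ; a stereocentre at a saturated ring carbon is drawn R in compound 3 and S in compound 4. The drawn configuration at one saturated ring carbon is the sole distinction. Among the compounds with values here, no measured pair here shows what a change of configuration does in this assay, and the three values gathered so far all sit in one band. The expectation is therefore no step beyond the scatter in either direction. The estimated step is a 1.0-fold lower number from compound 3 to compound 4 (0.01 log units; within the scatter). Compound 4 is expected to give 45000 nM, with a range from 20000 nM to 100000 nM.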

Compound 4, half-maximal inhibitory concentration: 64000 nM
The estimate for compound 4 lay 1.4-fold (0.15 log units) below the measured number; low and high end bracket the measured number.
By their numbers in this assay, from the lowest: compounds 1, 2, 3 and 4 (each within the scatter of the next, the first and the last beyond it).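

The series now holds its first measured step for a change of configuration, at the saturated ring carbon in this assay: a 1.4-fold higher number from compound 3 to compound 4 (0.14 log units; within the scatter). Going from the drawn R to the drawn S at this carbon therefore does not separate the two compounds in this assay, and on these readings this stereocentre shows no preference for either configuration. The pair holds everything else fixed, so the comparison speaks to one feature only: the fact that compounds 3 and 4 differ only in the configuration as drawn.

As far as these compounds go, whether configuration at this carbon would still make no measurable difference with another group in place of the thienyl group, such as an amine or a carboxylic acid, stays open. A single pair also cannot show whether a step beyond the scatter can arise at this position at all.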